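The source may hold more compounds than are shown below. What is called first, only, known or untested is meant among the compounds shown, and "the series" means these compounds.

Measured so far:
compound 1 `COc1ccc(-c2cc(/C=C/C(=O)c3ccc(N)cc3)[nH]n2)cc1` — 103%
compound 2 `COc1cc(-c2cc(/C=C/C(=O)c3ccc(N)cc3)[nH]n2)cc(OC)c1OC` — 95%

In a functional assay on MDA-MB-435 cells (Homo sapiens) for cytotoxicity, read by sulforhodamine B assay, with a stated time of 48 h, tested at 0.1 uM (on this read-out lower numbers stand for a stronger effect and higher numbers for a weaker effect at the one concentration tested), compound 2 gives 95%, and compound 1 gives 103%; the two numbers lie within the scatter of each other, so neither stands apart. Compound 3 `COc1cc(-c2cc(/C=C/C(=O)c3ccc(Cl)c(Cl)c3)[nH]n2)cc(OC)c1OC` differs from compound 2 in one place: 3,4-dichlorophenyl in place of 4-aminophenyl on a carbonyl carbon. For the measured compounds named here, no measured pair shows what such a change does here, so no step size is known. The expectation is that the step of a number 2 percentage points lower from compound 2 to compound 3 (within the scatter) stays within the scatter, with no clear direction. Compound 3 is therefore estimated at 93% in this assay, with a range from 72% to 108%.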

Compound 3, a percentage reported as activity, at one concentration (the size of the read-out at that concentration, not a potency): 96%
Beside the measured number, compound 3's estimate is 3 percentage points below it, within the range that was stated.
By their numbers in this assay, from the lowest: compounds 2, 3 and 1 (each within the scatter of the next).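

In this assay, 3,4-dichlorophenyl in place of 4-aminophenyl on a carbonyl carbon gives a number 1 percentage points higher from compound 2 to compound 3 (within the scatter) and leaves compounds with and without the amine indistinguishable at this one concentration. This position therefore tolerates the loss of the amine and the arrival of two chlorine atoms with no readable change in this read-out. No measured data here bear on the reason for this result.

Still open, going by these compounds, is whether a carboxylic acid or a longer chain on this phenyl ring would move the number. Also open, on these data alone, is whether a higher concentration would separate these compounds.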